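Cyclopropylsulfonyl to trifluoromethylsulfonyl on the sulfonamide aryl ring

The compounds below may be only part of what the source reports. "The series", "measured", "known", "first", "only" and "open" are said of these compounds alone.

Measured so far in an assay for binding affinity to Apoptosis regulator Bcl-2 (Homo sapiens), read by fluorescence polarization, with a stated time of 2 h; a lower number here means a stronger inhibitor, a higher number a weaker inhibitor:
compound 1 `CCCn1c(C)c(C(=O)O)c(-c2cccc(N3CCN(c4ccc(NS(=O)(=O)c5ccc(N[C@H](CCN6CCC(O)CC6)CSc6ccccc6)c(S(=O)(=O)C(F)(F)F)c5)cc4)CC3)c2)c1-c1ccc(Cl)cc1` gives 7.5 nM
compound 2 `Cc1c(C(=O)O)c(-c2cccc(N3CCN(c4ccc(NS(=O)(=O)c5ccc(N[C@H](CCN6CCC(O)CC6)CSc6ccccc6)c(S(=O)(=O)C(F)(F)F)c5)cc4)CC3)c2)c(-c2ccc(Cl)cc2)n1C` gives 2.4 nM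
compound 3 `Cc1c(C(=O)NCCCN2CCN(C)CC2)c(-c2cccc(N3CCN(c4ccc(NS(=O)(=O)c5cccc(S(=O)(=O)C6CC6)c5)cc4)CC3)c2)c(-c2ccc(Cl)cc2)n1C` gives 218 nM

Compound 3 carries the highest number of the three in this assay, well beyond the scatter from both compound 1 and compound 2; those two also differ from compound 3 in several other places, so their numbers say nothing about one change alone.

Compound 4 `Cc1c(C(=O)NCCCN2CCN(C)CC2)c(-c2cccc(N3CCN(c4ccc(NS(=O)(=O)c5cccc(S(=O)(=O)C(F)(F)F)c5)cc4)CC3)c2)c(-c2ccc(Cl)cc2)n1C` differs from compound 3 in one place: trifluoromethyl in place of cyclopropyl on a sulfonyl sulfur. Within the data shown here, no measured pair here shows this change by itself, so its size cannot be read from the data.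

Expectation for compound 4: a step of a 1.5-fold lower number from compound 3 to compound 4 (0.16 log units; within the scatter) in this assay, likely within or near the scatter. Compound 4 is estimated at 150 nM, within 50 nM to 500 nM.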

Compound 4, inhibition constant: 39.2 nM
Compound 4: the middle estimate sits 3.8-fold (0.58 log units) above what was measured, outside the stated range (below it).
By their numbers in this assay, from the lowest: compound 2; then compound 1; then compound 4; then compound 3.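

On a sulfonyl sulfur whose other neighbour is aromatic carbon, trifluoromethyl in place of cyclopropyl gives a 5.6-fold lower number from compound 3 to compound 4 (0.75 log units; beyond the scatter) in this assay. Among these compounds, this is the only single change that can be read so far, and it shows that the group on this sulfur alone moves the number beyond the scatter. Nothing measured here explains the step.

As far as these compounds go, whether the step carries over to compounds with the carboxylic acid of compound 2 remains open. So does where a methyl or a longer alkyl chain on this sulfur would fall.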